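The compounds below may be only part of what the source reports. "The series", "measured", "known", "first", "only" and "open" are said of these compounds alone.

Measured so far in a functional assay on PC-3 cells (Homo sapiens) for antiproliferative activity, read by sulforhodamine B assay, with a stated time of 48 h; a lower number here means a stronger inhibitor of growth, a higher number a weaker inhibitor of growth:
- Compound 1 `O=C(/C=C/c1cccc(S(=O)(=O)c2ccc3ccccc3n2)c1)NO`: 150 nM
- Compound 2 `O=C(/C=C/c1ccc(S(=O)(=O)c2ccc3ccccc3n2)cc1)NO`: 490 nM
- Compound 3 `COc1ccc2nc(S(=O)(=O)c3cccc(/C=C/C(=O)NO)c3)ccc2c1`: 280 nM

Compound 3 gives 280 nM, a number within the usual scatter of those for both compound 1 and compound 2, so it cannot be ranked against either of them.

Compound 4 `O=C(/C=C/c1cccc(S(=O)(=O)c2ccc3cc(Cl)ccc3n2)c1)NO` has not yet been measured. It differs from compound 3 in one place, with chloro in place of methoxy on an aromatic carbon.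

For the measured compounds named here, only one measured step bears on this change, methoxy in place of hydrogen on an aromatic carbon. That step is a 1.9-fold higher number from compound 1 to compound 3 (0.27 log units; within the scatter), which stays within the scatter. Going by the values given here, no compound with chloro has been measured, so this evidence is indirect. Going by that single step, no change beyond the scatter is expected in this assay.

The estimate is a small step, a 1.4-fold lower number from compound 3 to compound 4 (0.15 log units; within the scatter), expected to stay within the scatter. The expected value for compound 4 is 200 nM, with an estimated range from 90 nM to 450 nM.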

Compound 4, concentration for 50% growth inhibition: 760 nM
Compound 4: middle estimate off by 3.8-fold (0.58 log units), on the low side; the whole stated range lies below it.
By their numbers in this assay, from the lowest: compounds 1, 3, 2 and 4 (each within the scatter of the next, the first and the last beyond it).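

In this assay the group at this position of the shared core now clearly matters: chloro in place of methoxy gives a 2.7-fold higher number from compound 3 to compound 4 (0.43 log units; beyond the scatter) and chloro in place of hydrogen gives a 5.1-fold higher number from compound 1 to compound 4 (0.70 log units; beyond the scatter) on the same core. Methoxy in place of hydrogen gave only a 1.9-fold higher number from compound 1 to compound 3 (0.27 log units; within the scatter) and stayed within the scatter, so among these three compounds chloro is the one group that moves the number beyond it, towards weaker inhibition of growth. Nothing available here explains why chloro differs from the other two groups.

Going by these compounds, whether fluoro, bromo, an amine or a carboxylic acid at this position would behave like chloro or like methoxy remains open. So does whether chloro would give a similar step on the core of compound 2.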